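This account rests on a few compounds, and the source may have more. Where it says the series, first, only, none or still open, it means among the compounds named here.

Measured so far:
compound 1 `CNC(=O)c1cc(C(=O)NC2CCC2)cn(Cc2ccccn2)c1=O` — 2.2
compound 2 `CNC(=O)c1cc(C(=O)NC2CC2)c(C)n(Cc2ccccc2)c1=O` — 2.9
compound 3 `CNC(=O)c1cc(C(=O)NC2CC2)cn(Cc2cccc3cc[nH]c23)c1=O` — 3.7

In a physicochemical assay for lipophilicity, at pH 7.4 (on this read-out lower numbers stand for lower lipophilicity and higher numbers for higher lipophilicity), compound 3 gives the highest of the three numbers: compound 2 sits a gap below it that exceeds the scatter, and compound 1 sits further below still. Compound 4 `CNC(=O)c1cc(C(=O)NC2CC2)cn(Cc2cccc(C)c2)c1=O` has not yet been measured in this assay. It differs from compound 3 in one place: 3-methylphenyl in place of 1H-indol-7-yl on a saturated chain carbon bound to an aromatic nitrogen. Going by the values given here, no two of the measured compounds differ in one place only, so no single step is available for comparison; compound 2, which also carries a benzyl-type group and a cyclopropyl amide, gives 2.9 and is the nearest reference. For compound 4 a modest step downward is expected, a number 0.50 log units lower from compound 3 to compound 4 (beyond the scatter), roughly at the edge of the scatter. Compound 4 is therefore estimated at 3.2, within 2.7 to 3.7.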

Compound 4, distribution coefficient: 3.6
The estimate for compound 4 lay 0.40 log units below the measured number; measured number inside the range.
By their numbers in this assay, from the lowest: compound 1; then compound 2; then compounds 4 and 3 (each within the scatter of the next).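

In this assay, going by these compounds alone, the first single-place comparison at this position reads a number 0.10 log units lower from compound 3 to compound 4 (within the scatter) and so does not separate 3-methylphenyl from 1H-indol-7-yl on a saturated chain carbon bound to an aromatic nitrogen. The numbers stay level even though the change removes the five-membered aromatic ring and the hydrogen-bond donor. Nothing available explains this result. Going by these compounds, what an amine or a carboxylic acid in place of 3-methylphenyl would give remains open. Compound 1 and compound 2 differ from compound 4 in more than one place, so they cannot settle this.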